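From Methoxybenzyl to Dichlorobenzyl: What Compound 3 Might Show

The compounds below may be only part of what the source reports. "The series", "measured", "known", "first", "only" and "open" are said of these compounds alone.

Among the compounds with values here, compound 2 `COc1ccc(CNC(=O)c2c([N+](=O)[O-])noc2-c2ccc(Cl)cc2)cc1` is one of only two compounds measured so far in an ADME assay on J774.A1 cells (Mus musculus) for cytotoxicity, read by MTT assay, with a stated time of 48 h (on this read-out lower numbers stand for higher toxicity in this test and higher numbers for lower toxicity in this test), where compound 2 gives 89500 nM. Within the data shown here, its sole neighbour, compound 1 `O=C(Nc1ccccc1)c1c([N+](=O)[O-])noc1-c1ccc(Cl)cc1`, gives 89300 nM in this assay, and the two numbers lie within the scatter of each other; the step of a 1.0-fold higher number from compound 1 to compound 2 (0.00 log units; within the scatter) shows that the change on the amide-type nitrogen left the read-out flat. Compound 3 `O=C(NCc1cccc(Cl)c1Cl)c1c([N+](=O)[O-])noc1-c1ccc(Cl)cc1` differs from compound 2 by 2,3-dichlorophenyl in place of 4-methoxyphenyl on a saturated chain carbon bound to an amide-type nitrogen. Among the measured compounds shown here, the only measured step that bears on this change is that from compound 1 to compound 2, and it was flat; nothing measured speaks to a dichlorophenyl group in this place. The account therefore expects a step of a 1.2-fold lower number from compound 2 to compound 3 (0.08 log units; within the scatter), most likely nothing beyond the scatter. The estimate for compound 3 in this assay is 75000 nM, with a range from 25000 nM to 160000 nM.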

Compound 3, half-maximal cytotoxic concentration: 73700 nM
Compound 3: the middle estimate sits 1.0-fold (0.01 log units) above what was measured; the measured number falls inside the stated range.
By their numbers in this assay, from the lowest: compounds 3, 1 and 2 (each within the scatter of the next).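

In this assay this place on the amide-type nitrogen now also carries a chlorinated ring, and 2,3-dichlorophenyl in place of 4-methoxyphenyl gives a 1.2-fold lower number from compound 2 to compound 3 (0.08 log units; within the scatter) while 2,3-dichlorobenzyl in place of phenyl gives a 1.2-fold lower number from compound 1 to compound 3 (0.08 log units; within the scatter) for this pair. The earlier compounds had shown only that phenyl and 4-methoxybenzyl read alike; the 2,3-dichlorobenzyl group, with two chlorine atoms where the 4-methoxyphenyl group has its oxygen, joins them with no step beyond the scatter. Nothing at hand explains why the three read alike.

Going by these compounds, it remains open whether a carboxylic acid or an amine on this ring, or a longer chain to the amide-type nitrogen, would give a step beyond the scatter. On these data alone, the shared core is the same in all three compounds, so its part in the read-out also stays open.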